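Removing a Methoxy Group at Two Different Places

The source may report more compounds than this note shows. Statements on the series, on what has been measured and on what is new or still open speak of the compounds shown alone.

Measured compounds:
compound 1, `COc1ccc(-c2cc(C(=O)Nc3nc4ccc(Cl)cc4s3)nc3cc(-c4ccccc4)nn23)cc1OC`, 6910 nM in a functional assay on MCF7 cells (Homo sapiens) for cytotoxicity, read by MTT assay, with a stated time of 48 h; a lower number here means a stronger inhibitor, a higher number a weaker inhibitor
compound 2, `COc1cc(-c2cc(C(=O)Nc3nc4ccc(Cl)cc4s3)nc3cc(-c4ccccc4)nn23)cc(OC)c1OC`, 30200 nM
compound 3, `COc1ccc(-c2cc(C(=O)Nc3nc4ccc(OC)cc4s3)nc3cc(-c4ccccc4)nn23)cc1`, 19100 nM

Of the compounds shown here, three sharing a common core have been measured in this assay. Compound 2 and compound 1 differ in one place: hydrogen in place of methoxy on an aromatic carbon. That step gave a 4.4-fold lower number from compound 2 to compound 1 (0.64 log units; beyond the scatter). Compound 3 stands apart from compound 2 in more than one place; the difference between the two cores is not broken down here. Its value in this assay lies near that of compound 2, while against compound 1 it shows a higher number.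

Compound 4, `COc1ccc(-c2cc(C(=O)Nc3nc4ccccc4s3)nc3cc(-c4ccccc4)nn23)cc1`, has not yet been measured. It differs from compound 3 in one place: hydrogen in place of methoxy on an aromatic carbon. Among the measured compounds shown here, this is the same kind of change as the one from compound 2 to compound 1, but the surroundings differ. In the earlier pair the carbon was ortho to a methoxy group, meta to a large group and meta to a methoxy group; here it sits on a ring that is part of a fused system of two rings, meta to a fused ring and para to a fused ring. For the measured compounds named here, only one earlier example of this kind of change exists, and it sits on a different ring, so the step it gave is a weak guide. A step of a 1.6-fold lower number from compound 3 to compound 4 (0.20 log units; within the scatter) is expected from compound 3 to compound 4, resting on the direction seen in the earlier pair but tempered for the different place. Compound 4 is therefore estimated at 12000 nM in this assay, within a range from 4000 nM to 40000 nM.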

Compound 4, half-maximal inhibitory concentration: 2230 nM
Compound 4: the middle estimate sits 5.4-fold (0.73 log units) above what was measured; the measured number lies below the stated range.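

In this assay, hydrogen in place of methoxy on the 6-methoxy-1,3-benzothiazol-2-yl group gave an 8.6-fold lower number from compound 3 to compound 4 (0.93 log units; beyond the scatter), so the same kind of change lowered the number in both pairs shown, and in each pair the step lies beyond the scatter. Set side by side, the two steps run in the same direction and cannot be told apart in size: the same change on two cores in this assay, a 4.4-fold lower number (0.64 log units; beyond the scatter) from compound 2 to compound 1 and an 8.6-fold lower number (0.93 log units; beyond the scatter) from compound 3 to compound 4, 2.0-fold (0.29 log units) apart, within the scatter of two such steps. Among the compounds shown here, this shows that, across these two pairs, the loss of a methoxy group went with a lower number whether it left the benzothiazole part or the methoxy-bearing aryl group, but it does not establish a rule for the series, since there are only two examples, they sit at different places on different rings, and neither place is tested on a second core.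

The compounds shown leave open whether the lower number would hold if the hydrogen on the benzothiazole ring were replaced by a group other than methoxy, such as a hydroxyl group, an amine or a carboxylic acid. They also leave open whether the phenyl group on the shared core, unchanged throughout, would tolerate a similar change, for instance a methoxy group or a fluorine atom placed on it.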